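Dimethylamino for methoxy on a weakly active triazole

This account rests on a few compounds, and the source may have more. Where it says the series, first, only, none or still open, it means among the compounds named here.

Compound 1 `COc1ccc(-n2c(SCC(=O)c3ccc(OC)c(O)c3)nnc2-c2cc(OC)c(OC)c(OC)c2)cc1`: > 60000 nM, a limit of the assay
Compound 2 `COc1ccc(NC(=O)CSc2nnc(-c3cc(OC)c(OC)c(OC)c3)n2-c2ccc(OC)cc2)cc1`: 45300 nM

In a functional assay on HT-29 cells (Homo sapiens) for inhibition, read by MTT assay, with a stated time of 48 h (a lower number here means a stronger inhibitor, a higher number a weaker inhibitor), compound 2 gives 45300 nM, the only number shown. Compound 1 reaches only a limit (the limit of > 60000 nM in this assay, at which 1 of the 2 values shown sits). The step of an at least 1.3-fold lower number from compound 1 to compound 2 (0.12 log units; that floor lies within the scatter) lies within the scatter. Compound 3 `COc1ccc(NC(=O)CSc2nnc(-c3cc(OC)c(OC)c(OC)c3)n2-c2ccc(N(C)C)cc2)cc1` differs from compound 2 by dimethylamino in place of methoxy on an aromatic carbon. Going by the values given here, no measured step touches this position; the single step of an at least 1.3-fold lower number from compound 1 to compound 2 (0.12 log units; that floor lies within the scatter) concerns another group and was within the scatter, so no change beyond the scatter is expected in this assay. The expected step is a 1.1-fold lower number from compound 2 to compound 3 (0.05 log units; within the scatter). Compound 3 is estimated at 40000 nM, ranging from 15000 nM to 100000 nM.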

Compound 3, half-maximal inhibitory concentration: 51400 nM
Beside the measured number, compound 3's estimate is 1.3-fold (0.11 log units) below it, within the range that was stated.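

In this assay, the change from 4-methoxyphenyl to 4-(dimethylamino)phenyl gives a 1.1-fold higher number from compound 2 to compound 3 (0.05 log units; within the scatter). This position, on an aromatic carbon para to a large group, therefore takes dimethylamino in place of methoxy with no change beyond the scatter, and compound 2 and compound 3 cannot be told apart. Compound 1 alone sits at a limit of the assay: the limit of > 60000 nM in this assay, at which 1 of the 3 values shown sits. The compounds shown leave open whether a carboxylic acid or a primary amine at this position would move the number beyond the scatter.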